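Swapping thiophene for furan on a dimethyl-substituted aniline core

The source may hold more compounds than are shown below. What is called first, only, known or untested is meant among the compounds shown, and "the series" means these compounds.

Of the compounds shown here, three have been measured in a functional assay for inhibition, with Homo sapiens as the target; on this read-out higher numbers stand for weaker inhibition and lower numbers for stronger inhibition. Compound 1 `Cc1cccc(Nc2nccc(-c3cccs3)n2)c1` gives 300 nM. Compound 2 `Cc1cccc(Nc2nccc(-c3ccco3)n2)c1` gives 2100 nM. Compound 3 `Cc1cc(C)cc(Nc2nccc(-c3cccs3)n2)c1` gives 4300 nM, the highest of the three numbers. Compound 4 `Cc1cc(C)cc(Nc2nccc(-c3ccco3)n2)c1` has not yet been measured.

Two single changes link the measured compounds. The change furan-2-yl in place of thiophen-2-yl on an aromatic carbon made the step of a 7.0-fold higher number from compound 1 to compound 2 (0.85 log units; beyond the scatter). The change methyl in place of hydrogen on an aromatic carbon made the step of a 14-fold higher number from compound 1 to compound 3 (1.16 log units; beyond the scatter); this is also how the core of compound 3 differs from the core of compound 1.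

Compound 4 arises from compound 3 by furan-2-yl in place of thiophen-2-yl on an aromatic carbon. For the measured compounds named here, this is the same kind of change as the one from compound 1 to compound 2; the surroundings differ only in that the place is meta to a group of 9 heavy atoms rather than a group of 8 heavy atoms. A step of similar size is expected here because a 7.0-fold higher number from compound 1 to compound 2 (0.85 log units; beyond the scatter) was seen for the same kind of change, so the expected step is a 5.8-fold higher number from compound 3 to compound 4 (0.76 log units; beyond the scatter). In this assay compound 4 is therefore estimated at 25000 nM, expected to lie between 8000 nM and 80000 nM.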

Compound 4, half-maximal inhibitory concentration: 700 nM
For compound 4 the middle estimate is 36-fold (1.55 log units) above the measured one; the measured number lies below the stated range.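

In this assay, furan-2-yl in place of thiophen-2-yl gives a 6.1-fold lower number from compound 3 to compound 4 (0.79 log units; beyond the scatter), so the swap that raised the number on the core of compound 1 lowers it on the core of compound 3, and the two steps clearly disagree: the same change on two cores in this assay, a 7.0-fold higher number (0.85 log units; beyond the scatter) from compound 1 to compound 2 and a 6.1-fold lower number (0.79 log units; beyond the scatter) from compound 3 to compound 4, 43-fold (1.63 log units) apart, beyond the scatter of two such steps

The added methyl reverses in the same way, giving a 3.0-fold lower number from compound 2 to compound 4 (0.48 log units; beyond the scatter) when furan-2-yl is present, whereas it raised the number when thiophen-2-yl was present: the same change on two cores in this assay, a 14-fold higher number (1.16 log units; beyond the scatter) from compound 1 to compound 3 and a 3.0-fold lower number (0.48 log units; beyond the scatter) from compound 2 to compound 4, 43-fold (1.63 log units) apart, beyond the scatter of two such steps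

Across these four compounds, then, neither change can be carried to another core as a fixed step, since its direction depends on what sits at the other place; this does not show why the two places depend on each other, or whether the same holds beyond these compounds.

Going by these compounds, it remains open whether a phenyl ring in place of the five-membered ring would follow the thiophen-2-yl or the furan-2-yl pattern. On these data alone, it also remains open whether a chlorine or a methoxy group in place of the added methyl would produce the same reversal.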